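The compounds below may be only part of what the source reports. "The series", "measured", "known", "first", "only" and "open" are said of these compounds alone.

Of the compounds shown here, two have been measured so far. Compound 1 `Cc1ccc(NC(=O)N[C@@H](C)c2ccccc2)cc1` and compound 2 `CCc1ccccc1NC(=O)N[C@@H](C)c1ccccc1` share the same core and differ only in their aromatic substituents. In an ADME assay on the whole organism with Oryza sativa as the target, tested at 0.1 uM (a lower number here means a stronger effect, a higher number a weaker effect of the compound at the concentration tested), compound 1 gives 100% and compound 2 gives 100%, so compound 1 stands level with compound 2 at the digits reported, within the usual scatter.

Compound 3 `CCc1ccc(NC(=O)N[C@@H](C)c2ccccc2)cc1` has not yet been measured. It differs from compound 1 in one place: methyl in place of hydrogen on a saturated chain carbon bound to an aromatic carbon. Among the compounds with values here, no measured pair shows this kind of change, so nothing is known about its effect from the data themselves. Because compound 1 gives 100% and compound 2 gives 100%, both already at the top of the scale, no shift beyond the scatter is expected here. In this assay compound 3 is therefore expected to give 100%, within a range from 88% to 108%. The step of no change at the digits printed from compound 1 to compound 3 (within the scatter) is expected to be none beyond the scatter.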

Compound 3, a percentage reported as activity, at one concentration (the size of the read-out at that concentration, not a potency): 99%
Compound 3: middle estimate off by 1 percentage points, on the high side, within the range that was stated.
By their numbers in this assay, from the lowest: compounds 3, 1 and 2 (each within the scatter of the next).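

Methyl in place of hydrogen on a saturated chain carbon bound to an aromatic carbon, which can also be read one bond further out as methyl to ethyl, gives in this assay a number 1 percentage points lower from compound 1 to compound 3 (within the scatter). Within the data shown here, this is the first step that can be read at a single place, and it shows that this added methyl leaves the read-out unchanged at the concentration tested. Nothing at hand gives a reason for this outcome.

As far as these compounds go, whether a longer chain such as propyl, or a different group at this place such as an amine or a carboxylic acid, would move the number beyond the scatter remains open. Also open, from the compounds shown here alone, is whether this same change would read alike at another concentration, as all the values shown come from a single one.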